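Turning the ring stereocentre of compound 1

This account rests on a few compounds, and the source may have more. Where it says the series, first, only, none or still open, it means among the compounds named here.

compound 1 `O=C(Nc1cc2cc[nH]c(=O)c2cc1Cl)[C@H]1CCCN1` gives 0.283 h
compound 2 `CC(C)N[C@H](C(=O)Nc1cc2cc[nH]c(=O)c2cc1Cl)C1CCCCC1` gives 0.283 h

In an in vitro ADME assay on microsomes from liver (Homo sapiens) for metabolic stability, tested at 1 mg/mL (a lower number here means that the compound disappears faster, a higher number that the compound lasts longer), compound 1 gives 0.283 h and stands level with compound 2 at 0.283 h within the scatter. Compound 3 `O=C(Nc1cc2cc[nH]c(=O)c2cc1Cl)[C@@H]1CCCN1` is still unmeasured. It keeps the atoms and bonds of compound 1 the two compounds have the same atoms and bonds and differ only in configuration as drawn: 1 of 1 stereo elements differ; a stereocentre at a saturated ring carbon is drawn R in compound 1 and S in compound 3 with a stereocentre at a saturated ring carbon drawn R in compound 1 and S in compound 3. Among the compounds with values here, no measured pair shows what such a change does. The expected step is a 1.1-fold higher number from compound 1 to compound 3 (0.03 log units; within the scatter) and no size beyond the scatter is expected. Compound 3 is expected at about 0.3 h with an estimated range from 0.17 h to 0.65 h in this read-out.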

Compound 3, half-life: 0.267 h
Estimate against measurement, compound 3: 1.1-fold (0.05 log units) above, and the stated range covers the measured number.
By their numbers in this assay, from the lowest: compounds 3, 1 and 2 (each within the scatter of the next).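

Turning the stereocentre at the saturated ring carbon from R to S gives a 1.1-fold lower number from compound 1 to compound 3 (0.03 log units; within the scatter) in this assay and so leaves the half-life unmoved at this position. Unlike the earlier compounds, this pair differs in one place only, so the effect of configuration here can be read on its own: the fact that compounds 1 and 3 differ only in the configuration as drawn.

The compounds shown leave open whether the same indifference to configuration holds once a fluorine or a methyl ester sits on that saturated ring.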